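Aryl replacements on the shared core: pyrazine to isothiazole

The compounds below may be only part of what the source reports. "The series", "measured", "known", "first", "only" and "open" are said of these compounds alone.

Measured so far in an in vitro assay on CHO cells for displacement of a labelled ligand from Bombesin receptor subtype-3 (Homo sapiens), read by scintillation counting, with a stated time of 2 h; a higher number here means a weaker inhibitor, a lower number a stronger inhibitor:
compound 1 `CCC(C)(C)Cc1c[nH]c(CCc2ccc(-c3cnccn3)cc2)n1` — 51 nM
compound 2 `CCC(C)(C)Cc1c[nH]c(CCc2ccc(-c3cccc(C#N)n3)cc2)n1` — 140 nM
compound 3 `c1ccc(-c2ccc(CCc3nc(CC4CCCC4)c[nH]3)cc2)nc1` — 177 nM

Compound 1 gives the lowest number of the three. The nearest is compound 2, reached by a 2.7-fold higher number from compound 1 to compound 2 (0.44 log units; beyond the scatter). Compound 3 stands further off with a higher number than compound 1, but it differs from compound 1 at two places at once, so only the two values themselves are known for that pair.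

The unmeasured compound 4 `CCC(C)(C)Cc1c[nH]c(CCc2ccc(-c3cnsc3)cc2)n1` keeps the core of compound 1 and changes only the aromatic group: 1,2-thiazol-4-yl in place of pyrazin-2-yl on an aromatic carbon. Going by the values given here, the one measured step that bears on this is the exchange of the same pyrazin-2-yl for another ring in compound 2: modest, beyond the scatter, towards a higher number. Among the compounds with values here, a five-membered ring in place of a six-membered one is a further departure, and no measured pair tests that kind of exchange, so the spread around any expectation must be wide.

For compound 4 a modest rise in this assay is expected, a 2.0-fold higher number from compound 1 to compound 4 (0.29 log units; within the scatter). Compound 4 is estimated at 100 nM, with a range from 35 nM to 300 nM.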

Compound 4, half-maximal inhibitory concentration: 10 nM
For compound 4 the middle estimate is 10-fold (1.00 log units) above the measured one; measured number outside the range, below it.
By their numbers in this assay, from the lowest: compound 4; then compound 1; then compounds 2 and 3 (each within the scatter of the next).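

In this assay, going by these compounds alone, the only earlier step at this aromatic carbon, a 2.7-fold higher number from compound 1 to compound 2 (0.44 log units; beyond the scatter), ran upward, whereas 1,2-thiazol-4-yl moves the number the other way, a 5.1-fold lower number from compound 1 to compound 4 (0.71 log units; beyond the scatter), so pyrazin-2-yl is not the best-performing group that this position can carry. Against 6-cyanopyridin-2-yl the gap is wider, a 14-fold lower number from compound 2 to compound 4 (1.15 log units; beyond the scatter), which shows that the choice of aromatic group alone can change the number substantially on this core, and that a five-membered aromatic ring can stand here in place of a six-membered one; the count of hetero atoms, the count of hydrogen-bond acceptors and the absence of a net charge are the same for pyrazin-2-yl and 1,2-thiazol-4-yl, so these counts do not separate the two groups. No measurement available here gives a reason for the shift.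

With a single five-membered ring in the set, ring size cannot be separated from the presence of sulfur or from the arrangement of the ring atoms, and thiophen-3-yl and 1,3-thiazol-5-yl would bear on that question. On these data alone, whether 1,2-thiazol-4-yl gives a similar step alongside the cyclopentylmethyl group of compound 3 also remains open.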